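Methyl on a Ring Nitrogen: Expected Solubility of Compound 4

The source may report more compounds than this note shows. Statements on the series, on what has been measured and on what is new or still open speak of the compounds shown alone.

Of the compounds shown here, three sharing one core have been measured in a physicochemical assay for solubility, in phosphate buffer, measured as kinetic solubility; a lower number here means a less soluble compound, a higher number a more soluble compound. Compound 1 `CC(C)[C@@H](C[C@H]1SC(=O)NC1=O)c1ccc(-c2ccc3cccc(F)c3c2)[nH]c1=O` gives 23900 nM. Compound 2 `CC(C)C(c1ccc(-c2ccc3cccc(F)c3c2)[nH]c1=O)C1SC(=O)NC1=O` gives 20100 nM in this assay. Compound 3 `CC(C)C(/C=C1\NC(=O)NC1=O)c1ccc(-c2ccc3cccc(F)c3c2)[nH]c1=O` gives 10700 nM in this assay, the lowest of the three numbers; its nearest neighbour is compound 2, a gap within the usual scatter, while compound 1 stands beyond it.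

Within the data shown here, the single measured step, a 1.9-fold lower number from compound 2 to compound 3 (0.27 log units; within the scatter), swaps one five-membered ring for another and is small. The next compound, compound 4 `CC(C)C(/C=C1/C(=O)NC(=O)N1C)c1ccc(-c2ccc3cccc(F)c3c2)[nH]c1=O`, differs from compound 3 as follows: methyl in place of hydrogen on an amide-type nitrogen in a ring. Among the measured compounds shown here, no measured pair shows a methyl entering on an amide-type nitrogen; that one step bears on the question only loosely, as the sole sign that a change on this ring moves the numbers in this assay little. With nothing pointing clearly up or down, the expected step is a 1.1-fold lower number from compound 3 to compound 4 (0.03 log units; within the scatter), none beyond the scatter. Compound 4 is therefore expected to give about 10000 nM in this assay, within a range from 4000 nM to 25000 nM.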

Compound 4, solubility: 34800 nM
Compound 4: the middle estimate sits 3.5-fold (0.54 log units) below what was measured, and the stated range ends below it.
By their numbers in this assay, from the lowest: compounds 3, 2, 1 and 4 (each within the scatter of the next, the first and the last beyond it).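

Among these compounds, the ring nitrogen turns out to be a place where even a single added carbon can count in this assay: putting methyl in place of the amide hydrogen gives a 3.3-fold higher number from compound 3 to compound 4 (0.51 log units; beyond the scatter), whereas the one earlier step involving this ring, a 1.9-fold lower number from compound 2 to compound 3 (0.27 log units; within the scatter), stayed within the scatter. The ring bearing the methyl also cannot be told apart from the ring group of compound 2, since the step between those two compounds, a 1.7-fold higher number from compound 2 to compound 4 (0.24 log units; within the scatter), lies within the scatter even though the step from compound 3 does not. No measurement shown here gives a reason for the effect of the methyl on this nitrogen.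

This single pair leaves open whether an ethyl group, a longer chain or a chain ending in a carboxylic acid on the same amide-type nitrogen would move the number in the same direction, or by a similar amount. It also leaves open whether methyl on the amide-type nitrogen in the ring of compound 2 would produce a step of similar size, or whether this result belongs to the ring of compound 3 alone.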